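Aniline replacement on the shared core: compound 4

This account rests on a few compounds, and the source may have more. Where it says the series, first, only, none or still open, it means among the compounds named here.

Measured so far:
compound 1 `FC(F)(F)c1ccc(CSc2nc(Nc3cccc(C(F)(F)F)c3)c3ccccc3n2)cc1` gives 11100 nM
compound 2 `FC(F)(F)c1ccc(CSc2nc(Nc3cccc(Br)c3)c3ccccc3n2)cc1` gives 22100 nM
compound 3 `O=[N+]([O-])c1cccc(Nc2nc(SCc3ccc(C(F)(F)F)cc3)nc3ccccc23)c1` gives 31500 nM

Among the measured compounds shown here, in a functional assay on MDA-MB-231 cells (Homo sapiens) for cytotoxicity, read by MTT assay, with a stated time of 72 h (on this read-out higher numbers stand for weaker inhibition and lower numbers for stronger inhibition), the number for compound 1 stands lowest of the three, though the gap to compound 2, a 2.0-fold higher number from compound 1 to compound 2 (0.30 log units; within the scatter), is within the scatter; only the step to compound 3, a 2.8-fold higher number from compound 1 to compound 3 (0.45 log units; beyond the scatter), goes beyond it, and a 1.4-fold higher number from compound 2 to compound 3 (0.15 log units; within the scatter) is again within the scatter. Compound 4 `COc1ccc(Nc2nc(SCc3ccc(C(F)(F)F)cc3)nc3ccccc23)c(OC)c1` is not yet measured. It departs from compound 1 as follows: 2,4-dimethoxyphenyl in place of 3-(trifluoromethyl)phenyl on a nitrogen on an aromatic ring.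

For the measured compounds named here, every measured step so far keeps the aryl group on the nitrogen and alters only the substituent on one aromatic carbon, and each swap away from trifluoromethyl gave a higher number. The change to compound 4 is larger than any of those: the whole 3-(trifluoromethyl)phenyl is exchanged for a 2,4-dimethoxyphenyl, a group with two hydrogen-bond acceptors where the leaving group had none. Going by the values given here, no measured pair shows this kind of exchange, so the precedent is indirect. On the pattern that departures from compound 1 have so far raised the number, compound 4 is expected to show a 2.0-fold higher number from compound 1 to compound 4 (0.30 log units; within the scatter). Compound 4 is therefore estimated at 22000 nM, within a range of 8000 nM to 60000 nM.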

Compound 4, half-maximal inhibitory concentration: > 50000 nM
Compound 4 was reported as a limit; the forecaster's own chance of this, stated with the estimate: 15%; at least 2.2-fold (0.35 log units) between middle value and limit.
By their numbers in this assay, from the lowest: compounds 1, 2 and 3 (each within the scatter of the next, the first and the last beyond it). At a limit, above all of these: compound 4.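

In this assay compound 4 carries no number but a limit: the limit of > 50000 nM in this assay, at which 1 of the 4 values shown sits. Among the compounds shown here, exchanging the whole aryl group on the nitrogen, rather than one substituent on it, gives an at least 4.5-fold higher number from compound 1 to compound 4 (0.65 log units; beyond the scatter) and also an at least 2.2-fold higher number from compound 2 to compound 4 (0.35 log units; beyond the scatter), which shows that this position is not indifferent to a 2,4-dimethoxyphenyl, the first entering group here that brings hydrogen-bond acceptors to the aryl group without a nitro group. Against the nitro analogue the reading is an at least 1.5-fold higher number from compound 3 to compound 4 (0.20 log units; that floor lies within the scatter), and with that floor inside the scatter, no order can be stated between compound 3 and compound 4.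

For the compounds shown here, the single step to compound 4 changes the substituents and their places on the aryl group together, and it remains open whether one methoxy group alone would carry the same shift in this assay. On these data alone, what an amine or a carboxylic acid on that aryl group would do also stays open, as does any change to the 4-(trifluoromethyl)benzyl group on sulfur, which all four compounds share.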